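One Measured Anchor and an Aryl Swap

The compounds below may be only part of what the source reports. "The series", "measured", "known", "first", "only" and "open" are said of these compounds alone.

Three compounds share one core: compound 1 `CCCCOC(=O)CC1c2cccc(C)c2S(=O)(=O)N1C(=O)OC`, compound 2 `CCCCOC(=O)CC1c2cccc(C)c2S(=O)(=O)N1C(=O)/C=C/c1cc(F)cc(Cl)c1` and compound 3 `CCCCOC(=O)CC1c2cccc(C)c2S(=O)(=O)N1C(=O)c1ccc(Cl)cc1`. In an assay on HEK-Blue hNOD1 cells for antagonist activity at Nucleotide-binding oligomerization domain-containing protein 1 (Homo sapiens), read by reporter gene assay, with stated times of 3 h and 20 h (a higher number here means a weaker inhibitor, a lower number a stronger inhibitor), compound 1 gives "not determined" (no result reported) and compound 2 gives "not determined" (no result reported), so for these two no result was reported. In this assay, within the data shown here, compound 3 gives 2140 nM, the only number available, so compound 3 stands alone and no comparison with the others is possible. Compound 4 `CCCCOC(=O)CC1c2cccc(C)c2S(=O)(=O)N1C(=O)c1cccc(C(F)(F)F)c1` is not yet measured; it differs from compound 3 in one place: 3-(trifluoromethyl)phenyl in place of 4-chlorophenyl on a carbonyl carbon. Among the measured compounds shown here, with no measured pair from which a step could be read, there is no basis for expecting a move in either direction beyond the scatter. The estimate for compound 4 in this assay is therefore 2500 nM, with a range from 800 nM to 8000 nM. The expected step of a 1.2-fold higher number from compound 3 to compound 4 (0.07 log units; within the scatter) is estimated to stay within the scatter.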

Compound 4, half-maximal inhibitory concentration: 1050 nM
Compound 4: the middle estimate sits 2.4-fold (0.38 log units) above what was measured, and the stated range covers the measured number.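

In this assay, 3-(trifluoromethyl)phenyl in place of 4-chlorophenyl on the carbonyl carbon gives a 2.0-fold lower number from compound 3 to compound 4 (0.31 log units; beyond the scatter). Among these compounds, this is the first step that can be read, and it shows that the number responds to a change in the aryl group at this place on the shared core. Nothing available bears on the reason for this step.

This single step cannot separate the effect of losing the chlorine from that of gaining the trifluoromethyl group. Going by these compounds, how a plain phenyl, a pyridine ring, or an aryl group carrying an amine or a carboxylic acid would behave here remains open.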